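Three Hydrazones Measured, a 4-Chlorophenyl Analogue Awaited

This account rests on a few compounds, and the source may have more. Where it says the series, first, only, none or still open, it means among the compounds named here.

Compound 1 `CC(/C=N/Nc1ccc([N+](=O)[O-])cc1)=N\NC(=O)c1ccccc1Cl` gives in a functional assay on cells (Splenocyte, Mus musculus, strain BALB/c) for inhibition, read by scintillation counting and thymidine incorporation, with a stated time of 72 h (a lower number here means a stronger inhibitor, a higher number a weaker inhibitor), a value of > 12000 nM, which is a limit of the assay rather than a number.
Compound 2 `CC(/C=N/Nc1ccc([N+](=O)[O-])cc1)=N\NC(=O)c1ccccc1F` gives in this assay > 12000 nM, again only a limit.
Compound 3 `CC(/C=N/N(C)c1ccc([N+](=O)[O-])cc1)=N\NC(=O)c1ccccc1O` gives in this assay 3120 nM.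

Compound 2 therefore stands at the limit of > 12000 nM in this assay, at which 2 of the 3 values shown sit. Among the compounds with values here, the only step between compounds that differ in one place, a step that the two limits leave unreadable from compound 1 to compound 2, is unreadable for that reason. Within the data shown here, compound 3 differs from the others in more than one place, so it yields no single step.

Compound 4 `CC(/C=N/Nc1ccc([N+](=O)[O-])cc1)=N\NC(=O)c1ccc(Cl)cc1` differs from compound 2 by 4-chlorophenyl in place of 2-fluorophenyl on a carbonyl carbon. No readable step bears on this change, so no step beyond the scatter is expected in this assay. Compound 4 is estimated at 15000 nM (range 4000 nM to 60000 nM), an expected step that the limit leaves unreadable from compound 2 to compound 4, most likely again reported only as a limit.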

Compound 4, half-maximal inhibitory concentration: 4200 nM
The estimate for compound 4 lay 3.6-fold (0.55 log units) above the measured number; the measured number falls inside the stated range.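

Within the data shown here, on the carbonyl carbon, the choice of group proves readable for the first time: 4-chlorophenyl in place of 2-fluorophenyl gives an at least 2.8-fold lower number from compound 2 to compound 4 (0.45 log units; beyond the scatter) in this assay, and 4-chlorophenyl in place of 2-chlorophenyl gives an at least 2.8-fold lower number from compound 1 to compound 4 (0.45 log units; beyond the scatter). The earlier step between compounds differing in one place could not be read. The full size of both new steps remains unknown because each starts from a limit: the limit of > 12000 nM in this assay, at which 2 of the 4 values shown sit.

On these data alone, how a plain phenyl or a phenyl carrying an amine or a carboxylic acid would compare with 4-chlorophenyl at this position remains open.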